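Chloro for hydroxy: a cytotoxicity step still to be read

The source may report more compounds than this note shows. Statements on the series, on what has been measured and on what is new or still open speak of the compounds shown alone.

Compound 2 `O=C(c1ccncc1)N1N=C(c2cc3ccccc3o2)CC1c1ccc(O)cc1` is the measured starting point. In an ADME assay on Vero cells (Chlorocebus sabaeus) for cytotoxicity, read by MTT assay, with a stated time of 72 h (on this read-out lower numbers stand for stronger inhibition and higher numbers for weaker inhibition), compound 2 gives > 200000 nM, which is a limit of the assay and not a number. For the measured compounds named here, its only measured neighbour, compound 1 `COc1ccc(C2CC(c3cc4ccccc4o3)=NN2C(=O)c2ccncc2)c(O)c1`, stands in the same place: in this assay compound 1 gives > 190000 nM, again a limit rather than a number. Going by the values given here, the single measured step, a step that the two limits leave unreadable from compound 1 to compound 2, is unreadable, since both ends rest at the limits the limit of > 190000 nM in this assay, at which 1 of the 2 values shown sits, and (the limit of > 200000 nM in this assay, at which 1 of the 2 values shown sits). Compound 3 `O=C(c1ccncc1)N1N=C(c2cc3ccccc3o2)CC1c1ccc(Cl)cc1` differs from compound 2 by chloro in place of hydroxy on an aromatic carbon. Among the compounds with values here, no measured step speaks to this change, and the two limits give no size to work from. Compound 3 is therefore expected to remain near the limit, the step of an at least 1.3-fold lower number from compound 2 to compound 3 (0.12 log units; that floor lies within the scatter) being only a cautious guess. Compound 3 is estimated at 150000 nM, within a range from 40000 nM to 300000 nM.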

Compound 3, half-maximal inhibitory concentration: > 220000 nM
Compound 3 gave a limit, no number (the forecaster's own chance of this, stated with the estimate: 60%); at least 1.4-fold (0.16 log units) between middle value and limit.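

In this assay compound 3 gives > 220000 nM, a limit of the assay and not a number. Its steps from compound 1 and from compound 2 cannot be read. The compounds shown leave open what size, if any, the change from hydroxy to chloro has on this read-out.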